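The source may report more compounds than this note shows. Statements on the series, on what has been measured and on what is new or still open speak of the compounds shown alone.

Measured so far in an ADME assay on microsomes from liver (Rattus norvegicus) for metabolic stability (a lower number here means that the compound disappears faster, a higher number that the compound lasts longer), with each value a limit of the assay and not a number:
compound 1 `N#Cc1ccc(NCCNc2ncc(-c3ncc[nH]3)c(-c3ccc(Cl)cc3Cl)n2)nc1` gives > 0.5 h
compound 2 `Clc1ccc(-c2nc(NCCNc3ccccn3)ncc2-c2ncc[nH]2)c(Cl)c1` gives > 0.5 h
compound 3 `Nc1nc(NCCNc2ncc(-c3ncc[nH]3)c(-c3ccc(C(F)(F)F)cc3)n2)ccc1[N+](=O)[O-]` gives > 0.5 h

Compound 3 has no exact place on the scale, since it sits with the other two at the limit of > 0.5 h in this assay, at which 3 of the 3 values shown sit, and nothing finer can be read. Compound 4 `Nc1nc(NCCNc2ncc(-c3ncc[nH]3)c(-c3cc(F)ccc3F)n2)ccc1[N+](=O)[O-]` differs from compound 3 in one place: 2,5-difluorophenyl in place of 4-(trifluoromethyl)phenyl on an aromatic carbon. Within the data shown here, the only measured step, a step that the two limits leave unreadable from compound 1 to compound 2, is a different change and offers no size to carry over. No step beyond the usual scatter can be argued for in either direction, so none is expected, and the estimated change is a step that the limit leaves unreadable from compound 3 to compound 4. For compound 4 the expected half-life is 0.7 h with an estimated range of 0.35 h to 1.5 h. Compound 4 may again turn out as only a limit of the assay.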

Compound 4, half-life: > 0.5 h
Compound 4: only a limit was reported (the forecaster's own chance of this, stated with the estimate: 70%); the middle value is on the limit's open side.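

No step can be read from compound 3 to compound 4, since both give a limit of the assay and not a number: the limit of > 0.5 h in this assay, at which 4 of the 4 values shown sit.

In this assay, from the compounds shown here alone, the exact half-life of all four compounds stays open, and so does whether 2,5-difluorophenyl or 4-(trifluoromethyl)phenyl gives the longer one.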